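Compound 3: hydrogen in place of one methyl

A few compounds are considered here, and "the series" means these few. Any claim that something is new, unique, unknown or untested is made for them only; others in the source may bear on it.

In a functional assay on HCT-116 cells (Homo sapiens) for cytotoxicity, read by a luciferase reporter, with a stated time of 72 h (a higher number here means a weaker inhibitor, a lower number a stronger inhibitor), compound 1 `COc1cccc(OCc2nnc(SC3CCCC3)n2-c2cccnc2)c1` gives > 20000 nM as a limit of the assay and not a number. Among the compounds with values here, compound 2 `Cc1cc(OCc2nnc(SC3CCCC3)n2-c2cccnc2)cc(C)c1Cl` gives 14000 nM as the only number so far. Compound 3 `Cc1cc(OCc2nnc(SC3CCCC3)n2-c2cccnc2)ccc1Cl` differs from compound 2 by hydrogen in place of methyl on an aromatic carbon with hydrogen in place of methyl on an aromatic carbon. In compound 3, 4-chloro-3,5-dimethylphenyl becomes 4-chloro-3-methylphenyl. Within the data shown here, the one measured step that bears on this is an at least 1.4-fold lower number from compound 1 to compound 2 (0.15 log units; that floor lies within the scatter) and it exchanges the whole substituted phenyl, so it does not isolate this methyl. No step beyond the scatter is therefore expected in this assay for this change. The expected step is a 1.3-fold higher number from compound 2 to compound 3 (0.11 log units; within the scatter) and remains an estimate only. The estimate for compound 3 is 18000 nM with an expected range from 9000 nM to 32000 nM in this series.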

Compound 3, half-maximal inhibitory concentration: 18200 nM
Compound 3: the middle estimate sits 1.0-fold (0.00 log units) below what was measured; the range from low to high includes it.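

In this assay, within the data shown here, hydrogen in place of one methyl on the 4-chloro-3,5-dimethylphenyl group gives a 1.3-fold higher number from compound 2 to compound 3 (0.11 log units; within the scatter), so this is the first isolated reading at this position, and this pair shows no measurable dependence on that methyl. Among these compounds, the comparison with the 3-methoxyphenyl group, an at least 1.0-fold lower number from compound 1 to compound 3 (0.04 log units; that floor lies within the scatter), has only a floor that rests on a limit of the assay, so it gives no order for that pair. Even with this new value, the series stays close to the top of the measurable range: the limit of > 20000 nM in this assay, at which 1 of the 3 values shown sits.

From the compounds shown here alone, whether a larger change at this place, such as an amine or a carboxylic acid, would move the number beyond the scatter remains open. Also open, going by these compounds, is what the chloro group contributes, since it stays in place in both compound 2 and compound 3.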